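The source may hold more compounds than are shown below. What is called first, only, known or untested is meant among the compounds shown, and "the series" means these compounds.

Compound 3 `CNC(=O)c1cc(Oc2ccc3nc(NC(=O)Nc4ccc(Cl)cc4)sc3c2)ccn1` stands highest of the three numbers in a functional assay on HCT-116 cells (Homo sapiens) for inhibition, read by MTT assay, with a stated time of 2 days, tested at 10 uM (on this read-out lower numbers stand for less inhibition of growth and higher numbers for more inhibition of growth at the one concentration tested), where compound 3 gives 57.4%. Its nearest neighbour is compound 1 `CNC(=O)c1cc(Oc2ccc3nc(NC(=O)c4ccc(Cl)cc4)sc3c2)ccn1`, which in this assay gives 27.5%; the step from the aryl amide to the aryl urea runs a number 29.9 percentage points higher from compound 1 to compound 3 (beyond the scatter). Furthest away is compound 2 `CNC(=O)c1cc(Oc2ccc3nc(NC(=O)Nc4ccc(N5CCN(C)CC5)cc4)sc3c2)ccn1`, which in this assay gives 24.6%; exchanging its 4-methylpiperazin-1-yl group for chloro gives the step of a number 32.8 percentage points higher from compound 2 to compound 3 (beyond the scatter).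

Compound 4 `CNC(=O)c1cc(Oc2ccc3nc(NC(=O)Nc4ccc(C5CCN(C(C)C)CC5)cc4)sc3c2)ccn1` differs from compound 3 in one place: 1-isopropylpiperidin-4-yl in place of chloro on an aromatic carbon. Among the compounds with values here, the step that bears on this change is the one from compound 2 to compound 3, since it also exchanges a saturated six-membered nitrogen-containing ring at the same position of the urea aryl group against chloro, and it was large. The change from compound 3 to compound 4 runs in the opposite direction, putting such a ring back in place of chloro, so a drop in this assay of a size similar to that step is expected, although the isopropyl-bearing piperidinyl ring is not the same group as the methylpiperazinyl of compound 2. Compound 4 is therefore expected to show a step of a number 27.4 percentage points lower from compound 3 to compound 4 (beyond the scatter), landing at an estimated 30%, with a range from 12% to 50%.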

Compound 4, percent growth inhibition at one concentration: 68.1%
Compound 4: the middle estimate sits 38.1 percentage points below what was measured; measured number outside the range, above it.
By their numbers in this assay, from the lowest: compounds 2 and 1 (each within the scatter of the next); then compound 3; then compound 4.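

The piperidine ring of compound 4 shows that a large, saturated, nitrogen-containing ring at this place on the urea aryl group does not by itself lower the number in this assay: 1-isopropylpiperidin-4-yl in place of chloro gives a number 10.7 percentage points higher from compound 3 to compound 4 (beyond the scatter). Among these compounds, the low number of compound 2 therefore belongs to the 4-methylpiperazin-1-yl group in particular and not to ring-bearing groups here in general, as 1-isopropylpiperidin-4-yl in its place gives a number 43.5 percentage points higher from compound 2 to compound 4 (beyond the scatter). Nothing available explains why these two groups, which each bring a six-membered non-aromatic ring to the same aromatic carbon, stand so far apart.

The two groups differ in the ring atom bonded to the aromatic carbon, in the second ring nitrogen and in the alkyl group on nitrogen, so the compounds shown leave open which of these differences matters; a 1-methylpiperidin-4-yl or a 4-isopropylpiperazin-1-yl group at this place would begin to separate them. From the compounds shown here alone, it also remains open whether 1-isopropylpiperidin-4-yl would give a similar gain on the aryl amide of compound 1.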